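The compounds below may be only part of what the source reports. "The series", "measured", "known", "first", "only" and "open" are said of these compounds alone.

Compound 1 `COc1ccc2nc(C)cc(OCC(=O)NCc3cc(C)cc(C)c3)c2c1` and compound 2 `COc1ccc2nc(C)cc(OCC(=O)Nc3ccc(Br)c(C)c3)c2c1` share a core and differ only in the group carried on the amide-type nitrogen. In a physicochemical assay for solubility, in phosphate buffer, measured as kinetic solubility, with a stated time of 1 h, at pH 7.4 (on this read-out lower numbers stand for lower solubility and higher numbers for higher solubility), compound 1 gives 92000 nM. For compound 2 the same assay reports only a limit, < 1000 nM, so no exact number is known for it. Going by the values given here, the single measured step, an at least 92-fold lower number from compound 1 to compound 2 (1.96 log units; beyond the scatter), is therefore a large drop, and compound 2 stands at the lower edge of what has been seen, resting at the limit of < 1000 nM in this assay, at which 1 of the 2 values shown sits.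

Compound 3 `COc1ccc2nc(C)cc(OCC(=O)Nc3ccccn3)c2c1` is the next member. The change from compound 2 is pyridin-2-yl in place of 4-bromo-3-methylphenyl on an amide-type nitrogen. Among the compounds with values here, no measured step follows this exact change; the only step known, from a benzyl-type group to an aryl group on the same nitrogen, was large. Because compound 2 sits at < 1000 nM, the starting point for compound 3 is itself uncertain. Compound 3 is expected to show a modest rise, an at least 4.0-fold higher number from compound 2 to compound 3 (0.60 log units; beyond the scatter), rather than a step beyond the scatter. Compound 3 is thus estimated at 4000 nM, with a likely range from 700 nM to 30000 nM.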

Compound 3, solubility: 29000 nM
Compound 3: the middle estimate sits 7.3-fold (0.86 log units) below what was measured; the measured number falls inside the stated range.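

In this assay, exchanging only the group on the amide-type nitrogen gives an at least 29-fold higher number from compound 2 to compound 3 (1.46 log units; beyond the scatter), so this position can move the number strongly upward even when an aromatic ring stays directly on the nitrogen, which the earlier pair could not show. Measured against the 3,5-dimethylbenzyl group, pyridin-2-yl gives a 3.2-fold lower number from compound 1 to compound 3 (0.50 log units; beyond the scatter), a modest step, whereas 4-bromo-3-methylphenyl gave a large one; the large drop therefore did not come simply from removing the benzyl-type link in every case shown. The true size of the rise remains open-ended, since the number for compound 2 is only a limit: the limit of < 1000 nM in this assay, at which 1 of the 3 values shown sits.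

The change to pyridin-2-yl brings in a ring nitrogen and removes the bromine and the methyl all at once, and the compounds shown do not separate these parts. A plain phenyl group on the same nitrogen would help to tell them apart, and a pyridin-2-ylmethyl group would show how the ring nitrogen fares when the benzyl-type link is kept.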